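This account rests on a few compounds, and the source may have more. Where it says the series, first, only, none or still open, it means among the compounds named here.

Measured compounds:
compound 1 `O=C(Nc1cc(C(F)(F)F)cc(C(F)(F)F)c1)C1CCc2ccccc2N1C(=O)c1ccccc1Cl` — 4700 nM
compound 2 `O=C(Nc1ccccc1C(F)(F)F)C1CCc2ccccc2N1C(=O)c1ccccc1` — 8090 nM

Both numbers come from a functional assay on ACHN cells (Homo sapiens) for cytotoxicity, read by sulforhodamine B assay, with a stated time of 72 h; on this read-out higher numbers stand for weaker inhibition of growth and lower numbers for stronger inhibition of growth. Within the data shown here, compound 1 gives the lowest of the two numbers; the nearest is compound 2, whose number is higher by an amount that lies within the usual scatter, so the two values show only that the compounds are close. Compound 3 `O=C(Nc1cc(C(F)(F)F)cc(C(F)(F)F)c1)C1CCc2ccccc2N1` has not been measured. It differs from compound 1 in one place: hydrogen in place of (2-chlorophenyl)carbonyl on a nitrogen on an aromatic ring in a ring. Among the measured compounds shown here, no step of this kind between measured compounds is available, so the expectation rests on compound 1 alone and on the size of what is removed. The loss of a group of nine heavy atoms from the core of compound 1 is expected to weaken inhibition of growth, with the step of a 3.4-fold higher number from compound 1 to compound 3 (0.53 log units; beyond the scatter) expected to lie beyond the scatter. Compound 3 is therefore estimated at 16000 nM, with a range from 4500 nM to 60000 nM.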

Compound 3, concentration for 50% growth inhibition: 8190 nM
Compound 3: middle estimate off by 2.0-fold (0.29 log units), on the high side, and the stated range covers the measured number.
By their numbers in this assay, from the lowest: compounds 1, 2 and 3 (each within the scatter of the next).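

In this assay, hydrogen in place of (2-chlorophenyl)carbonyl on a nitrogen on an aromatic ring in a ring gives a 1.7-fold higher number from compound 1 to compound 3 (0.24 log units; within the scatter), the first step read at this position. The loss of 9 heavy atoms, including one six-membered aromatic ring of carbon only and a hydrogen-bond acceptor, therefore leaves the number within the scatter, so this pair gives no sign that growth inhibition in this assay depends on the (2-chlorophenyl)carbonyl group. No measurement is at hand that would explain this result.

From the compounds shown here alone, whether a small acetyl group, a benzyl group without the carbonyl, or a carbonyl group bearing an amine on this nitrogen would stay within the scatter of hydrogen remains open. So does whether the same exchange would give a similar step with a different group on the amide nitrogen.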